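Replacing dimethylamino with propyl on a pyrazole side chain

A few compounds are considered here, and "the series" means these few. Any claim that something is new, unique, unknown or untested is made for them only; others in the source may bear on it.

Measured so far:
compound 1, `CN1CCN(CCCNCc2cn(-c3ccc(C(F)(F)F)cc3)nc2-c2ccc(OC(F)(F)F)cc2)CC1`, 2300 nM
compound 2, `CN1CCN(CCCNCc2cn(-c3ccc([N+](=O)[O-])cc3)nc2-c2ccc(Cl)cc2)CC1`, 3700 nM
compound 3, `Cc1ccccc1-c1nn(-c2ccc(F)cc2F)cc1CNCCN(C)C`, > 20000 nM

In an ADME assay on Huh-7 cells (Homo sapiens) for cytotoxicity (on this read-out lower numbers stand for higher toxicity in this test and higher numbers for lower toxicity in this test), compound 1 gives 2300 nM and compound 2 gives 3700 nM. For compound 3 the result is only a limit of the assay, > 20000 nM, so it stands at the least toxic end of the numbers shown, with no exact figure; the limit is recorded as the limit of > 20000 nM in this assay, at which 1 of the 3 values shown sits.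

Compound 4, `CCCCCNCc1cn(-c2ccc(F)cc2F)nc1-c1ccccc1C`, has not yet been measured in this assay. It differs from compound 3 in one place: propyl in place of dimethylamino on a saturated chain carbon, two bonds along the chain from an amine nitrogen.

For the measured compounds named here, no step between measured compounds is available for this change, and the chain that carries it is the only part altered. Compound 4 is expected to remain at the weakly toxic end, with the step of an at least 1.3-fold lower number from compound 3 to compound 4 (0.12 log units; that floor lies within the scatter) likely within the scatter or a modest move toward higher toxicity. Compound 4 is therefore estimated at 15000 nM, with a range from 5000 nM to 40000 nM.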

Compound 4, half-maximal cytotoxic concentration: 17000 nM
For compound 4 the middle estimate is 1.1-fold (0.05 log units) below the measured one; low and high end bracket the measured number.
By their numbers in this assay, from the lowest: compounds 1 and 2 (each within the scatter of the next); then compound 4. At a limit, above all of these: compound 3.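

Exchanging dimethylamino for propyl on a saturated chain carbon, two bonds along the chain from an amine nitrogen, gives in this assay an at least 1.1-fold lower number from compound 3 to compound 4 (0.07 log units; that floor lies within the scatter). For the compounds shown here, this is the first reading at this position, and it shows that compound 4 keeps a measurable number in this assay without the terminal amine nitrogen of compound 3. The value of compound 3 is a limit of the assay, so the step is only a floor and its true size cannot be read: the limit of > 20000 nM in this assay, at which 1 of the 4 values shown sits.

The compounds shown leave open how a hydroxyl group, a carboxylic acid or a longer chain at this position would read in this assay. They also leave open whether the same exchange would give a similar step on the side chains of compound 1 and compound 2.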